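Swapping Methoxy for Chloro on the Aryl Ketone

The compounds below may be only part of what the source reports. "The series", "measured", "known", "first", "only" and "open" are said of these compounds alone.

Measured so far:
compound 1 `COc1ccc(C(=O)/C=C/c2cc(-c3cc(OC)c(OC)c(OC)c3)n3nc(-c4ccccc4)cc3n2)cc1` — 79800 nM
compound 2 `COc1ccc(C(=O)/C=C/c2cc(-c3ccc(OC)c(OC)c3)n3nc(-c4ccccc4)cc3n2)cc1` — 40000 nM

Compound 1 `COc1ccc(C(=O)/C=C/c2cc(-c3cc(OC)c(OC)c(OC)c3)n3nc(-c4ccccc4)cc3n2)cc1` holds the highest of the two numbers in an ADME assay on HEK293 cells (Homo sapiens) for antiproliferative activity, read by MTT assay, with a stated time of 24 h; a lower number here means a stronger inhibitor, a higher number a weaker inhibitor; in this assay compound 1 gives 79800 nM. Among the measured compounds shown here, its nearest neighbour, compound 2 `COc1ccc(C(=O)/C=C/c2cc(-c3ccc(OC)c(OC)c3)n3nc(-c4ccccc4)cc3n2)cc1`, gives 40000 nM, and the only measured step, a 2.0-fold lower number from compound 1 to compound 2 (0.30 log units; within the scatter), concerns a change at another place on the shared core. Compound 3 `COc1cc(-c2cc(/C=C/C(=O)c3ccc(Cl)cc3)nc3cc(-c4ccccc4)nn23)cc(OC)c1OC` differs from compound 1 by chloro in place of methoxy on an aromatic carbon. For the measured compounds named here, no measured step touches this position, so the data give no direct guide to the size or direction of the step. Going by the values given here, with the one step seen lying within the scatter, compound 3 is expected to stay close to compound 1, and the estimated step is a 1.3-fold lower number from compound 1 to compound 3 (0.12 log units; within the scatter). Compound 3 is therefore expected at 60000 nM, within a range from 20000 nM to 180000 nM.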

Compound 3, half-maximal inhibitory concentration: >= 100000 nM
Compound 3: a limit, no number; the forecaster's own chance of this, stated with the estimate: 20%; middle value at least 1.6-fold (0.22 log units) from the limit.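

Going from 4-methoxyphenyl to 4-chlorophenyl on the carbonyl is the first change at this position, and it gives an at least 1.2-fold higher number from compound 1 to compound 3 (0.09 log units; that floor lies within the scatter). The value for compound 3 in this assay is a limit of the assay and not a number: the limit of >= 100000 nM in this assay, at which 1 of the 3 values shown sits. As far as these compounds go, the true size of the step therefore stays unknown, and its floor alone does not separate chloro from methoxy at this position.

The compounds shown leave open whether an amine or a carboxylic acid in place of the methoxy would give a readable number in this assay, and whether any group here can give a lower number than compound 1 does. They also leave open whether chloro in place of methoxy would act the same way on the core of compound 2.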